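The source may hold more compounds than are shown below. What is called first, only, known or untested is meant among the compounds shown, and "the series" means these compounds.

In an ADME assay on Vero cells (Chlorocebus sabaeus) for cytotoxicity, read by MTT assay, with a stated time of 72 h (a higher number here means a weaker inhibitor, a lower number a stronger inhibitor), compound 1 `O=C(O)c1cn(C2CC2)c2nc(N3CCN(C(=O)C4COc5ccccc5O4)CC3)c([N+](=O)[O-])cc2c1=O`, which carries cyclopropyl on an aromatic nitrogen, gives 59900 nM. Compound 2 `O=C(O)c1cn(-c2ccc(F)cc2)c2nc(N3CCN(C(=O)C4COc5ccccc5O4)CC3)c([N+](=O)[O-])cc2c1=O` gives > 54300 nM, which is a limit of the assay and not a number. For compound 2 the evidence is therefore (the limit of > 54300 nM in this assay, at which 1 of the 2 values shown sits). Among the measured compounds shown here, the one measured step is a step that the limit leaves unreadable from compound 1 to compound 2, with 4-fluorophenyl in place of cyclopropyl on an aromatic nitrogen, and it offers no size to carry forward.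

Compound 3 `CC(C)(C)n1cc(C(=O)O)c(=O)c2cc([N+](=O)[O-])c(N3CCN(C(=O)C4COc5ccccc5O4)CC3)nc21` changes the same place: tert-butyl in place of 4-fluorophenyl on an aromatic nitrogen. With no readable step to go on, no change beyond the usual scatter is expected in this assay, and no direction can be assigned. For the measured compounds named here, the expectation rests mainly on compound 1 at 59900 nM, the only exact number available. The estimated step is a step that the limit leaves unreadable from compound 2 to compound 3. Compound 3 is expected at 60000 nM. Its estimated range runs from 30000 nM to 120000 nM, and the assay may equally report only a limit for it.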

Compound 3, half-maximal inhibitory concentration: 116000 nM
Estimate against measurement, compound 3: 1.9-fold (0.29 log units) below; the range from low to high includes it.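

In this assay, among the compounds shown here, tert-butyl in place of cyclopropyl on the aromatic nitrogen is the one change at this position whose size can be read, and it comes out as a 1.9-fold higher number from compound 1 to compound 3 (0.29 log units; within the scatter). This gives the position a second exact number, and it places cyclopropyl and tert-butyl, one a ring and the other not, within the scatter of each other. The steps that involve compound 2 cannot be read, as compound 2 carries only a limit of the assay: the limit of > 54300 nM in this assay, at which 1 of the 3 values shown sits.

The compounds shown leave open whether 4-fluorophenyl reads any differently from cyclopropyl or tert-butyl, and whether any group on this aromatic nitrogen can move the number beyond the scatter. A longer chain such as n-butyl, or a chain ending in an amine such as 2-aminoethyl, would be a further test of this position on the same core.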